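The source may report more compounds than this note shows. Statements on the series, on what has been measured and on what is new or still open speak of the compounds shown alone.

Compound 1 `CCCn1c(NC(=O)CCc2ccccc2)nc2cc(C(N)=O)cc(OC)c21`: > 100000 nM
Compound 2 `CCn1nccc1C(=O)Nc1nc2cc(C(N)=O)cc(OC)c2n1CCCNC(=O)OCc1ccccc1`: > 100000 nM
Compound 3 `COc1cc(C(N)=O)cc2nc(NC(=O)c3cc4ccccc4n3C)n(CCCNC(=O)OCc3ccccc3)c12`: > 100000 nM

In an assay for activation of interferon regulatory factor 3 (Homo sapiens), read by a luciferase reporter, with a stated time of 20 h (on this read-out higher numbers stand for an effect only at larger amounts of compound and lower numbers for an effect already at smaller amounts), compound 3 reaches only a limit, > 100000 nM. Compound 1 likewise gives a limit, > 100000 nM. Compound 2 too gives a limit, > 100000 nM. Hence (the limit of > 100000 nM in this assay, at which 3 of the 3 values shown sit), and the step that the two limits leave unreadable from compound 2 to compound 3 cannot be sized. Compound 4 `COc1cc(C(N)=O)cc2nc(NC(=O)CCc3ccccc3)n(CCCNC(=O)OCc3ccccc3)c12` differs from compound 3 by phenethyl in place of 1-methyl-1H-indol-2-yl on a carbonyl carbon. Among the compounds with values here, the only measured step that touches this position, from compound 2 to compound 3, is unreadable, and compound 1, which carries the same phenethyl on its carbonyl carbon, sits at the limit. Compound 4 is therefore expected to stay at or near the limit, a number no higher from compound 3 to compound 4 (the limit leaves the size open) being no step beyond the scatter, with an estimate of 100000 nM (range 30000 nM to 300000 nM).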

Compound 4, half-maximal effective concentration: > 100000 nM
Compound 4 gave a limit, no number (the forecaster's own chance of this, stated with the estimate: 85%); the middle value lies on the limit itself.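

Compound 4 gives only a limit, so the steps to it from compound 1, compound 2 and compound 3 cannot be read: the limit of > 100000 nM in this assay, at which 4 of the 4 values shown sit.

The compounds shown leave open what any of these changes does to the read-out; none of them yields a number.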